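Swapping Allyl for Isobutyl on a Weak Inhibitor

A few compounds are considered here, and "the series" means these few. Any claim that something is new, unique, unknown or untested is made for them only; others in the source may bear on it.

Of the compounds shown here, two have so far been measured in a functional assay, read by spectrophotometry, with a stated time of 30 min; a lower number here means a stronger inhibitor, a higher number a weaker inhibitor. Compound 1 `C/C(=N\O)c1ccc([Te]CCCO)cc1` gives 13.1 ug/mL in this assay. Compound 2 `C=CCNC(C)c1ccc([Te]CCCC)cc1` reaches only the limit of the measurement, and in this assay compound 2 is reported as > 100 ug/mL; this is a limit rather than a number, and the limit of > 100 ug/mL in this assay, at which 1 of the 2 values shown sits, shows where it sits. For the measured compounds named here, because compound 2 stands at the limit of > 100 ug/mL in this assay, at which 1 of the 2 values shown sits, no measured step between the two compounds can be drawn, and their values are simply what they are.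

Compound 3 `CCCC[Te]c1ccc(C(C)NCC(C)C)cc1` has not yet been measured. It differs from compound 2 in a single place: isopropyl in place of vinyl on a saturated chain carbon bound to an amine nitrogen. Nothing measured speaks to this change, and no property of either group has been established here. With compound 2 resting at the limit, the step that the limit leaves unreadable from compound 2 to compound 3 is expected to be small or none beyond the scatter, in either direction. Compound 3 is therefore estimated at 120 ug/mL in this assay, with a range from 40 ug/mL to 400 ug/mL, and a substantial chance that this assay again returns only a limit.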

Compound 3, half-maximal inhibitory concentration: 12.5 ug/mL
Compound 3: the middle estimate sits 9.6-fold (0.98 log units) above what was measured; measured number outside the range, below it.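

In this assay, isopropyl in place of vinyl on a saturated chain carbon bound to an amine nitrogen gives an at least 8.0-fold lower number from compound 2 to compound 3 (0.90 log units; beyond the scatter). For the compounds shown here, this is the first readable sign that the group at this place matters: a change of this one group, with the rest of the structure kept, is enough to bring compound 3 to a measured 12.5 ug/mL. The step can be stated only as a lower bound, and its full size stays unknown, because compound 2 is held at a limit of the assay and not at a number: the limit of > 100 ug/mL in this assay, at which 1 of the 3 values shown sits.

Going by these compounds alone, the single step cannot separate what leaves from what enters, since the double bond goes and the isopropyl brings one more carbon and a branch, so a straight propyl in the same place is the comparison that would tell these apart. Going by these compounds, how far the place tolerates further change also remains open, whether with a longer chain, a cyclohexyl ring or a benzyl group, and whether any of these would carry the number in this assay lower still.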